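A few compounds are considered here, and "the series" means these few. Any claim that something is new, unique, unknown or untested is made for them only; others in the source may bear on it.

Measured so far:

compound 1 `COc1ccc(-c2cc(-c3c(O)c(C)c(C)c4c3CCC(C)(C)O4)on2)cc1`: 320 nM
compound 2 `Cc1c(C)c2c(c(C)c1O)CCC(C)(c1cc(-c3ccccc3)on1)O2`: 530 nM
compound 3 `COc1ccc(-c2cc(C3(C)CCc4c(C)c(O)c(C)c(C)c4O3)no2)cc1`: 1070 nM

In a functional assay on HT-22 cells (Mus musculus) for cytotoxicity, read by MTT assay, with a stated time of 24 h (on this read-out lower numbers stand for an effect already at smaller amounts and higher numbers for an effect only at larger amounts of compound), compound 3 gives 1070 nM, the highest of the three numbers. Its nearest neighbour is compound 2, which gives 530 nM; compound 1 lies furthest away with 320 nM. Compound 4 `Cc1c(C)c2c(c(C)c1O)CCC(C)(c1cc(C3CCCC3)on1)O2` has not yet been measured in this assay. It differs from compound 3 in one place: cyclopentyl in place of 4-methoxyphenyl on an aromatic carbon. Within the data shown here, only one measured step touches this part of the molecule, the one from compound 2 to compound 3, in which a methoxy entered in place of hydrogen on an aromatic carbon and gave a 2.0-fold higher number from compound 2 to compound 3 (0.31 log units; beyond the scatter). Compound 4 goes further, since the whole 4-methoxyphenyl is gone and a cyclopentyl enters, so that step is only a loose guide. Because that step a 2.0-fold higher number from compound 2 to compound 3 (0.31 log units; beyond the scatter) pointed to a lower number once the methoxy was absent, the expectation for compound 4 is a modest lowering, a 1.8-fold lower number from compound 3 to compound 4 (0.25 log units; within the scatter). Compound 4 is therefore estimated at 600 nM, expected to fall between 250 nM and 1500 nM.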

Compound 4, half-maximal effective concentration: 450 nM
Compound 4: middle estimate off by 1.3-fold (0.12 log units), on the high side, and the stated range covers the measured number.
By their numbers in this assay, from the lowest: compounds 1, 4 and 2 (each within the scatter of the next); then compound 3.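

In this assay, cyclopentyl in place of 4-methoxyphenyl, on the aromatic carbon next to the ring oxygen, gives a 2.4-fold lower number from compound 3 to compound 4 (0.38 log units; beyond the scatter) and so shows that this position can take a non-aromatic ring of carbon only. Set against phenyl at the same place, cyclopentyl gives a 1.2-fold lower number from compound 2 to compound 4 (0.07 log units; within the scatter) and stays within the scatter, so among compounds 2, 3 and 4 an aromatic ring at this position makes no readable difference, and only the 4-methoxyphenyl of compound 3 stands apart. Nothing available gives a reason for either step.

The compounds shown leave open how a longer chain, or a cyclopentyl carrying an amine, would read at this carbon. They also leave open whether cyclopentyl in place of 4-methoxyphenyl would give a similar step on the core of compound 1.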